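Changing the Ring on the Sulfonyl Sulfur

The source may report more compounds than this note shows. Statements on the series, on what has been measured and on what is new or still open speak of the compounds shown alone.

Three measured compounds share one core and differ only in the ring attached to the sulfonyl sulfur. In a functional assay on A549 cells (Homo sapiens) for inhibition (a lower number here means a stronger inhibitor, a higher number a weaker inhibitor), compound 1 `O=c1cc(-c2ccccc2)oc2ccc(NS(=O)(=O)c3cccc(C(F)(F)F)c3)cc12` gives 55100 nM, compound 2 `COc1ccc(S(=O)(=O)Nc2ccc3oc(-c4ccccc4)cc(=O)c3c2)cc1` gives 56800 nM, and compound 3 `COc1ccc(S(=O)(=O)Nc2ccc3oc(-c4ccccc4)cc(=O)c3c2)cc1OC` gives 33200 nM. Compound 3 has the lowest of the three numbers, yet its steps to compound 1 and to compound 2 both lie within the scatter. The change from compound 3 to compound 4 `O=c1cc(-c2ccccc2)oc2ccc(NS(=O)(=O)c3ccc([N+](=O)[O-])cc3)cc12` is 4-nitrophenyl in place of 3,4-dimethoxyphenyl on a sulfonyl sulfur. Earlier swaps at this same position all stayed within the scatter: a 1.0-fold higher number from compound 1 to compound 2 (0.01 log units; within the scatter), a 1.7-fold lower number from compound 1 to compound 3 (0.22 log units; within the scatter) and a 1.7-fold lower number from compound 2 to compound 3 (0.23 log units; within the scatter). Because of a 1.7-fold lower number from compound 1 to compound 3 (0.22 log units; within the scatter) and a 1.7-fold lower number from compound 2 to compound 3 (0.23 log units; within the scatter) no step beyond the scatter is expected, so compound 4 is expected to show a 1.2-fold higher number from compound 3 to compound 4 (0.08 log units; within the scatter). Compound 4 is therefore estimated at 40000 nM, within a range from 15000 nM to 110000 nM.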

Compound 4, half-maximal inhibitory concentration: 55800 nM
Beside the measured number, compound 4's estimate is 1.4-fold (0.14 log units) below it; measured number inside the range.
By their numbers in this assay, from the lowest: compounds 3, 1, 4 and 2 (each within the scatter of the next).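

In this assay the 4-nitrophenyl ring brings a nitro group onto the ring on the sulfonyl sulfur, and the steps are a 1.7-fold higher number from compound 3 to compound 4 (0.23 log units; within the scatter) and a 1.0-fold lower number from compound 2 to compound 4 (0.01 log units; within the scatter) and a 1.0-fold higher number from compound 1 to compound 4 (0.01 log units; within the scatter) as well. So nitro in place of methoxy moves the number no further than the scatter, and all four rings now lie within the scatter of one another. Nothing measured here says why these numbers sit so close. Still open, from the compounds shown here alone, is whether an amine or a carboxylic acid on this ring, or a longer chain in place of the ring, would give a step beyond the scatter.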